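This account rests on a few compounds, and the source may have more. Where it says the series, first, only, none or still open, it means among the compounds named here.

Measured so far in a functional assay on HepG2 cells (Homo sapiens) for antiproliferative activity, read by MTT assay, with a stated time of 24 h (on this read-out lower numbers stand for stronger inhibition and higher numbers for weaker inhibition), as the read-out:
compound 1 `O=S(=O)(c1ccc(F)cc1)n1c(-c2cn(-c3ccccc3)nc2-c2ccc(F)cc2)nc2ccccc21` (3520 nM)
compound 2 `O=S(=O)(c1ccccc1)n1c(-c2cn(-c3ccccc3)nc2-c2ccc(C(F)(F)F)cc2)nc2ccccc21` (590 nM)
compound 3 `Cc1ccc(C)c(S(=O)(=O)n2c(-c3cn(-c4ccccc4)nc3-c3ccc(C(F)(F)F)cc3)nc3ccccc32)c1` (330 nM)

Compound 3 at 330 nM is level, within the scatter, with compound 2 and lower than compound 1. Going to compound 4 `O=S(=O)(c1ccc(F)cc1)n1c(-c2cn(-c3ccccc3)nc2-c2ccc(C(F)(F)F)cc2)nc2ccccc21` puts 4-fluorophenyl in place of 2,5-dimethylphenyl on a sulfonyl sulfur and leaves the rest unchanged. Within the data shown here, the one measured change at that place, phenyl to 2,5-dimethylphenyl, is small: a 1.8-fold lower number from compound 2 to compound 3 (0.25 log units; within the scatter) and nothing more. Among the measured compounds shown here, compound 1 carries the same 4-fluorophenyl on its sulfonyl sulfur and gives 3520 nM but also differs from compound 4 elsewhere, and no measured pair separates the two changes. A step within the scatter is therefore expected in this assay with a slight lean toward a higher number. The estimated step is a 1.5-fold higher number from compound 3 to compound 4 (0.18 log units; within the scatter) for now. The estimated value for compound 4 is 500 nM (expected range 200 nM to 1300 nM)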

Compound 4, half-maximal inhibitory concentration: 2730 nM
Estimate against measurement, compound 4: 5.5-fold (0.74 log units) below; the measured number lies above the stated range.
By their numbers in this assay, from the lowest: compounds 3 and 2 (each within the scatter of the next); then compounds 4 and 1 (each within the scatter of the next).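

In this assay the group on the sulfonyl sulfur is no longer a place of small effects: the change to 4-fluorophenyl gives an 8.3-fold higher number from compound 3 to compound 4 (0.92 log units; beyond the scatter) and, as fluoro in place of hydrogen on an aromatic carbon, a 4.6-fold higher number from compound 2 to compound 4 (0.67 log units; beyond the scatter). Trifluoromethyl in place of fluoro on an aromatic carbon gives a 1.3-fold lower number from compound 1 to compound 4 (0.11 log units; within the scatter), so compound 1 and compound 4 stand level, and among the compounds shown, the two carrying 4-fluorophenyl on the sulfonyl sulfur share the higher numbers while phenyl and 2,5-dimethylphenyl stay level with each other. Nothing available accounts for the effect of the fluoro group.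

Open, going by these compounds, is whether chloro, methoxy or an amine in place of that fluoro would give the same step. Also open, on these data alone, is whether trifluoromethyl and fluoro remain level when the sulfonyl sulfur carries phenyl or 2,5-dimethylphenyl.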